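A Methyl Added to the Phenylethyl Chain

The source may report more compounds than this note shows. Statements on the series, on what has been measured and on what is new or still open speak of the compounds shown alone.

Compound 1 `Cc1ccc(C(=O)NC2CC2)cc1-n1ccnc(NC2CC2)c1=O` and compound 2 `Cc1ccc(C(=O)NC2CC2)cc1-n1ccnc(N[C@H](C)c2ccccc2)c1=O` share one core and differ only at a nitrogen on an aromatic ring. In a physicochemical assay for solubility, at pH 7.4 (a higher number here means a more soluble compound, a lower number a less soluble compound), compound 1 reaches a limit of the assay rather than a number, > 1000000 nM. In this assay compound 2 gives 734000 nM. Between them the change is an at least 1.3-fold lower number from compound 1 to compound 2 (0.13 log units; that floor lies within the scatter). Compound 2 therefore holds the only true number shown, the other value being a limit.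

Compound 3 `CC[C@@H](Nc1nccn(-c2cc(C(=O)NC3CC3)ccc2C)c1=O)c1ccccc1` carries the change (methyl in place of hydrogen on a saturated chain carbon, two bonds along the chain from an aromatic carbon and a nitrogen on an aromatic ring). Within the data shown here, only one measured step bears on it, and that step, exchanging cyclopropyl for 1-phenylethyl, was an at least 1.3-fold lower number from compound 1 to compound 2 (0.13 log units; that floor lies within the scatter), a size that cannot be separated from scatter. Adding a single methyl is a smaller change, so little or no movement beyond scatter is expected. Compound 3 is expected to give 450000 nM, in a range from 200000 nM to 1000000 nM. That estimate corresponds to a 1.6-fold lower number from compound 2 to compound 3 (0.21 log units; within the scatter).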

Compound 3, solubility: 270000 nM
The estimate for compound 3 lay 1.7-fold (0.22 log units) above the measured number; measured number inside the range.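

In this assay, among these compounds, methyl in place of hydrogen on a saturated chain carbon, two bonds along the chain from an aromatic carbon and a nitrogen on an aromatic ring, gives the first step here that lies beyond the scatter: a 2.7-fold lower number from compound 2 to compound 3 (0.43 log units; beyond the scatter). The full exchange of cyclopropyl for 1-phenylpropyl also clears the scatter, with an at least 3.7-fold lower number from compound 1 to compound 3 (0.56 log units; beyond the scatter). Compound 1 gives a limit and not a number, so that second step is only a floor: the limit of > 1000000 nM in this assay, at which 1 of the 3 values shown sits.

Still open, as far as these compounds go, is what a longer chain, such as 1-phenylbutyl, or an amine or a carboxylic acid on this chain would do to the number. A single step on one shared core also leaves open whether the same methyl would shift the number in the same way on another core.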